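The source may hold more compounds than are shown below. What is called first, only, known or untested is meant among the compounds shown, and "the series" means these compounds.

For the measured compounds named here, compound 1 `O=C1CC(c2ccc(Br)cc2)Oc2cc(OCc3cn(Cc4ccc(Br)cc4)nn3)ccc21` is the one compound of this set with a number attached: in an ADME assay on cells (Macrophage) for cytotoxicity, read by resazurin assay, with a stated time of 48 h (a higher number here means that more compound is tolerated, a lower number that less compound is tolerated), compound 1 gives 87500 nM, which puts it at a high concentration before macrophages are harmed. Going by the values given here, for its two companions no result in this assay was reported: compound 2 `CC(C)c1ccc(C2CC(=O)c3ccc(OCc4cn(Cc5ccc(Br)cc5)nn4)cc3O2)cc1` stands at "not determined" (no result reported), and compound 3 `O=C1CC(c2ccccc2)Oc2cc(OCc3cn(Cc4ccc(Br)cc4)nn3)ccc21` stands at "not determined" (no result reported), so compound 1 stands alone and no comparison among measured compounds can be drawn.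

The unmeasured compound 4 `CCCCCCn1cc(COc2ccc3c(c2)OC(c2ccc(Br)cc2)CC3=O)nn1` keeps the core of compound 1 and changes one group only: pentyl in place of 4-bromophenyl on a saturated chain carbon bound to an aromatic nitrogen. The bromine-bearing aromatic ring at that position is thus exchanged for a straight saturated chain of the same rough length.

Among the compounds with values here, with no measured pair to show how such a change moves tolerance in this assay, the expectation rests on compound 1 alone. The step from compound 1 to compound 4 is expected to be small, a 1.1-fold lower number from compound 1 to compound 4 (0.04 log units; within the scatter), and to stay within the usual scatter of this assay. Compound 4 is therefore estimated at 80000 nM, with a range from 30000 nM to 200000 nM, and it is expected that this assay may again report only a limit rather than a number for compound 4.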

Compound 4, half-maximal cytotoxic concentration: 20300 nM
Beside the measured number, compound 4's estimate is 3.9-fold (0.60 log units) above it; the whole stated range lies above it.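

For the compounds shown here, exchanging 4-bromophenyl for pentyl on a saturated chain carbon bound to an aromatic nitrogen gives a 4.3-fold lower number from compound 1 to compound 4 (0.63 log units; beyond the scatter) in this assay, the first measured change at this position. The step is modest but lies beyond the scatter, so what sits at this place does affect how much compound the macrophages tolerate: the version with the open chain is tolerated less well than the version with the bromine-bearing aromatic ring. Nothing shown here gives a reason for this drop.

As far as these compounds go, the ring and the bromine leave together in this single change, so it remains open which of the two matters, and how a plain benzyl, a longer chain such as octyl, or a hexyl chain ending in an amine would behave at this place. From the compounds shown here alone, the steps from compound 1 to compound 2 and to compound 3 cannot be read in this assay, so the effect of changes elsewhere on the shared core also remains open.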